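Inverting the chain stereocentre of compound 2

The source may hold more compounds than are shown below. What is called first, only, known or untested is meant among the compounds shown, and "the series" means these compounds.

- Compound 1 (`C[C@@H](Cn1ccc(-c2ccc(C#N)c(Cl)c2)n1)NC(=O)C1CC(=O)C1`): "not determined" (no result reported)
- Compound 2 (`C[C@@H](Cn1ccc(-c2ccc(C#N)c(Cl)c2)n1)Nc1ncnc2nc[nH]c12`): 4240 nM

For the measured compounds named here, in a functional assay on CWR22R cells (Homo sapiens) for antiproliferative activity, read by CCK-8 assay, with a stated time of 6 days (on this read-out lower numbers stand for stronger inhibition and higher numbers for weaker inhibition), compound 2 gives the only number (4240 nM), so it cannot be ranked against compound 1. Compound 3 (`C[C@H](Cn1ccc(-c2ccc(C#N)c(Cl)c2)n1)Nc1ncnc2nc[nH]c12`) differs from it in configuration alone: the two compounds have the same atoms and bonds and differ only in configuration as drawn: 1 of 1 stereo elements differ; a stereocentre at a saturated chain carbon is drawn S in compound 2 and R in compound 3. Going by the values given here, no measured step shows what such an inversion does, so no direction can be argued, and a change no larger than the usual scatter is expected. The expected change is a 1.1-fold lower number from compound 2 to compound 3 (0.03 log units; within the scatter), an estimate with wide uncertainty. Compound 3 is estimated at 4000 nM (expected range 1000 nM to 15000 nM).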

Compound 3, half-maximal inhibitory concentration: 10600 nM
Compound 3: the middle estimate sits 2.7-fold (0.42 log units) below what was measured; the measured number falls inside the stated range.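

In this assay, for the compounds shown here, the saturated chain carbon responds to its configuration, which no earlier compound could show: inversion from S to R gives a 2.5-fold higher number from compound 2 to compound 3 (0.40 log units; beyond the scatter) and this modest step lies beyond the usual scatter. Of this pair, the S form drawn in compound 2 holds the lower number. The step can be assigned to this stereocentre alone because of one fact: the fact that compounds 2 and 3 differ only in the configuration as drawn.

As far as these compounds go, whether the same preference for S would hold with an ethyl group in place of the chain methyl remains open. The compounds shown also leave open whether it extends to other groups on the chain nitrogen.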